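The source may report more compounds than this note shows. Statements on the series, on what has been measured and on what is new or still open speak of the compounds shown alone.

Series notes. The shared core of compound 1 `CCC(=O)NC(C)c1cc(Cl)c2cccnc2c1O` is the starting point. In an assay for inhibition of Polyunsaturated fatty acid lipoxygenase ALOX12 (Homo sapiens), read by spectrophotometry (a higher number here means a weaker inhibitor, a lower number a stronger inhibitor), compound 1 gives only a limit, > 50000 nM (the limit of > 50000 nM in this assay, at which 1 of the 2 values shown sits). Compound 2 `CCC(=O)NC(c1ccc(Br)o1)c1cc(Cl)c2cccnc2c1O` also gives only a limit in this assay, > 75000 nM (the limit of > 75000 nM in this assay, at which 1 of the 2 values shown sits). The step that the two limits leave unreadable from compound 1 to compound 2 is therefore left unreadable by the two limits. Compound 3 `CCC(=O)NC(c1ccc(F)cc1)c1cc(Cl)c2cccnc2c1O` differs from compound 2 by 4-fluorophenyl in place of 5-bromofuran-2-yl on a saturated chain carbon bound to an amide-type nitrogen and an aromatic carbon. For the measured compounds named here, no measured step reads on this change, and compound 2 stands at a limit, so little beyond the scatter is expected in this assay. The expected step is an at least 1.2-fold lower number from compound 2 to compound 3 (0.09 log units; that floor lies within the scatter). Compound 3 is estimated at 60000 nM, within 15000 nM to 250000 nM, in this assay.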

Compound 3, half-maximal inhibitory concentration: > 50000 nM
Compound 3 gave a limit, no number (the forecaster's own chance of this, stated with the estimate: 70%); the middle value lies beyond the limit too.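

For the compounds shown here, compound 1, compound 2 and compound 3 all give only limits in this assay, so no step among them can be read. The compounds shown leave open whether any group on the saturated chain carbon gives a measurable value.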